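Trimming a Cyclopropyl to a Methyl on the Shared Core

A few compounds are considered here, and "the series" means these few. Any claim that something is new, unique, unknown or untested is made for them only; others in the source may bear on it.

Two compounds have been measured so far:

Compound 1, `COc1nc2nc(C(=O)c3ccccc3)cn2c(C)c1CC1CC1`: 10 mg/kg in a functional assay on the whole organism with Rattus norvegicus as the target; a lower number here means that less compound is needed, a higher number that more compound is needed for the effect
Compound 2, `CCCc1c(OC)nc2nc(C(=O)c3ccccc3)cn2c1CC`: 10 mg/kg in this assay

Compound 1 stands level with compound 2 in this assay; the two values agree within the usual scatter, so nothing separates them on the numbers at hand. The next compound to be tested is compound 3, `CCc1c(OC)nc2nc(C(=O)c3ccccc3)cn2c1C`. It differs from compound 1 at a single place: methyl in place of cyclopropyl on a saturated chain carbon bound to an aromatic carbon. The shared core, the methoxy group and the benzoyl group are untouched by this change.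

Among the compounds with values here, no measured pair tracks this particular exchange, so there is no step to lean on. Compound 3 is expected to stay close to where compound 1 sits, with a step of no change at the digits printed from compound 1 to compound 3 (within the scatter) that would not go beyond the scatter, because compound 1 gives 10 mg/kg and the change is small. Compound 3 is therefore estimated at 10 mg/kg, within a range from 3 mg/kg to 30 mg/kg.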

Compound 3, minimum effective dose: 2 mg/kg
Estimate against measurement, compound 3: 5.0-fold (0.70 log units) above, and the stated range ends above it.
By their numbers in this assay, from the lowest: compound 3; then compounds 1 and 2 (each within the scatter of the next).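

This position is not indifferent to the group it carries. In this assay exchanging cyclopropyl for methyl gives a 5.0-fold lower number from compound 1 to compound 3 (0.70 log units; beyond the scatter) and so takes the value beyond the usual scatter, a modest but real step that the level values of the two earlier compounds could not reveal. Cut one bond further out, the same exchange turns cyclopropylmethyl into ethyl, so here the smaller group without a ring is the one that needs less compound for the effect. No measurement at hand gives a reason for this step.

Going by these compounds, with a single pair, it remains open whether the loss of the ring or the drop in heavy atoms matters. On these data alone, how a hydrogen, a longer chain such as butyl, or an amine would fare on this carbon also remains open.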